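Series notes: amine substituent at the pyridine nitrogen, stability

The compounds below may be only part of what the source reports. "The series", "measured", "known", "first", "only" and "open" are said of these compounds alone.

Compound 3 `FC(F)(F)c1cccc(-c2nc3cnc(Nc4cnccn4)cc3[nH]2)c1` stands lowest of the three measured compounds in an ADME assay on microsomes from liver (Mus musculus) for metabolic stability, read by LC-MS, with a stated time of 30 min, tested at 0.1 uM (on this read-out higher numbers stand for a more stable compound and lower numbers for a less stable compound), giving 7%. Compound 1 `COc1cccnc1Nc1cc2[nH]c(-c3cccc(C(F)(F)F)c3)nc2cn1` gives 80% in this assay, and compound 2 `COc1ccc(Nc2cc3[nH]c(-c4cccc(C(F)(F)F)c4)nc3cn2)nc1` gives 33%. Compound 4 `N#Cc1ccc(Nc2cc3[nH]c(-c4cccc(C(F)(F)F)c4)nc3cn2)nc1` carries 5-cyanopyridin-2-yl in place of pyrazin-2-yl on a nitrogen on an aromatic ring. Within the data shown here, the steps that bear on this change are a number 26 percentage points lower from compound 2 to compound 3 (beyond the scatter) and a number 73 percentage points lower from compound 1 to compound 3 (beyond the scatter); both run toward compound 3, so the return from pyrazin-2-yl to a substituted pyridin-2-yl is expected to recover some stability. Among the measured compounds shown here, no measured compound carries a nitrile, so the size is uncertain; compound 4 is expected to sit nearer compound 2 than compound 1, giving an estimated a number 21 percentage points higher from compound 3 to compound 4 (beyond the scatter). The estimate for compound 4 in this assay is 28%, with a range from 8% to 55%.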

Compound 4, percent of the compound remaining: 47%
For compound 4 the middle estimate is 19 percentage points below the measured one; measured number inside the range.
By their numbers in this assay, from the lowest: compound 3; then compound 2; then compound 4; then compound 1.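

In this assay, a number 40 percentage points higher from compound 3 to compound 4 (beyond the scatter) puts 5-cyanopyridin-2-yl clearly ahead of pyrazin-2-yl on this nitrogen. Cyano in place of methoxy on an aromatic carbon gives a number 14 percentage points higher from compound 2 to compound 4 (beyond the scatter), so the substituent alone moves this read-out with the rest of compound 2 unchanged. Even so, a number 33 percentage points lower from compound 1 to compound 4 (beyond the scatter) leaves 3-methoxypyridin-2-yl the highest of the groups shown.

No evidence is available to account for these steps. From the compounds shown here alone, whether a carboxamide or a methyl group in place of the nitrile would hold or raise this number remains open.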